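The source may report more compounds than this note shows. Statements on the series, on what has been measured and on what is new or still open speak of the compounds shown alone.

Measured so far in a functional assay on NCI-H460 cells (Homo sapiens) for cytotoxicity, read by sulforhodamine B assay (on this read-out higher numbers stand for weaker inhibition of growth and lower numbers for stronger inhibition of growth), are these values:
compound 1 `CC1=CC[C@@H]([C@@](C)(O)CCCC(C)(C)NC(=S)N/N=C\c2ccc(C)cc2)CC1` with 10100 nM
compound 2 `CC1=CC[C@@H]([C@@](C)(O)CCCC(C)(C)NC(=S)N/N=C\c2ccccc2[N+](=O)[O-])CC1` with 20600 nM
compound 3 `CC1=CC[C@@H]([C@@](C)(O)CCCC(C)(C)NC(=S)N/N=C\c2cccc([N+](=O)[O-])c2)CC1` with 8290 nM

Compound 1 stands inside the range of these three numbers, with a 1.2-fold lower number from compound 1 to compound 3 (0.09 log units; within the scatter) as its nearest step and a 2.0-fold higher number from compound 1 to compound 2 (0.31 log units; beyond the scatter) as its furthest.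

Compound 4 `CC1=CC[C@@H]([C@@](C)(O)CCCC(C)(C)NC(=S)N/N=C\c2cccc(Cl)c2)CC1` has not yet been measured. Its difference from compound 1 is 3-chlorophenyl in place of 4-methylphenyl on a carbon with a double bond to nitrogen in the form of 3-chlorophenyl in place of 4-methylphenyl on a carbon with a double bond to nitrogen.

The closest measured precedent is a 1.2-fold lower number from compound 1 to compound 3 (0.09 log units; within the scatter) where 3-nitrophenyl replaces the same 4-methylphenyl, and this step stays within the scatter. The other step, a 2.5-fold lower number from compound 2 to compound 3 (0.40 log units; beyond the scatter) is modest, and like the step from compound 1 to compound 2 it involves 2-nitrophenyl, which compound 4 does not carry. Within the data shown here, no compound with a chlorine has been measured, so the precedent is indirect.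

A step within the scatter is therefore expected in this assay with no firm direction. The expected step is a 1.2-fold lower number from compound 1 to compound 4 (0.07 log units; within the scatter) and nothing larger is estimated. For compound 4 the estimate is 8500 nM with an expected range from 4200 nM to 17000 nM on this read-out.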

Compound 4, concentration for 50% growth inhibition: 44300 nM
The estimate for compound 4 lay 5.2-fold (0.72 log units) below the measured number; measured number above the stated range.
By their numbers in this assay, from the lowest: compounds 3 and 1 (each within the scatter of the next); then compound 2; then compound 4.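

In this assay, 3-nitrophenyl and 3-chlorophenyl do not behave alike on this carbon: chloro in place of nitro gives a 5.3-fold higher number from compound 3 to compound 4 (0.73 log units; beyond the scatter), so the match between compound 1 and compound 3 does not carry over to the chloro compound. Against the 4-methylphenyl group, the change gives a 4.4-fold higher number from compound 1 to compound 4 (0.64 log units; beyond the scatter), and against the 2-nitrophenyl group it gives a 2.2-fold higher number from compound 2 to compound 4 (0.33 log units; beyond the scatter), which makes compound 4 the weakest growth inhibitor of the four and shows that 2-nitrophenyl no longer marks the weak end of the series. Nothing available on these compounds accounts for the separation between the chloro and nitro compounds.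

The compounds shown leave open whether 4-chlorophenyl or 2-chlorophenyl on this carbon would stand with compound 4 or with compound 1, which would tell the chlorine itself apart from its place on the ring. Also open, as far as these compounds go, is how groups such as 3-methoxyphenyl, 3-aminophenyl or 3-carboxyphenyl would sit relative to the nitro and chloro compounds.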